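A few compounds are considered here, and "the series" means these few. Any claim that something is new, unique, unknown or untested is made for them only; others in the source may bear on it.

Measured in a functional assay on HT-29 cells (Homo sapiens) for antiproliferative activity, read by MTT assay, with a stated time of 48 h; on this read-out higher numbers stand for weaker inhibition and lower numbers for stronger inhibition:

Compound 1 `COc1cc(N/C=C\C(=O)c2cn(-c3ccccc3)nc2-c2ccc(F)cc2)cc(OC)c1OC` gives 7770 nM.
Compound 2 `COc1cc(-c2nn(-c3ccccc3)cc2C(=O)/C=C\Nc2ccc(F)cc2)cc(OC)c1OC` gives 12500 nM.

Only these two numbers are known, and they sit close together: the gap between compound 1 and compound 2 is within the usual scatter of repeated measurements, so the two cannot be told apart on this evidence, and neither can be called the stronger or weaker of the pair. Compound 2 is the starting point for the next step.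

Compound 3 `COc1cc(-c2nn(-c3ccccc3)cc2C(=O)/C=C\Nc2ccc(Cl)cc2)cc(OC)c1OC` is the compound not yet measured. It differs from compound 2 in one spot: chloro in place of fluoro on an aromatic carbon. Everything else, including the shared core and the trimethoxyphenyl part, is kept.

Going by the values given here, with no measured pair showing what this particular swap does, the safest expectation is a small shift, with no clear direction, that stays within the scatter: the step from compound 2 to compound 3 in this assay is estimated to be a 1.3-fold lower number from compound 2 to compound 3 (0.10 log units; within the scatter). On that basis compound 3 is expected to give about 10000 nM in this assay, most likely between 4000 nM and 25000 nM.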

Compound 3, half-maximal inhibitory concentration: 7680 nM
Beside the measured number, compound 3's estimate is 1.3-fold (0.11 log units) above it, and the stated range covers the measured number.
By their numbers in this assay, from the lowest: compounds 3, 1 and 2 (each within the scatter of the next).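

This is the first pair shown that differs in one place only, so a single change can be read directly: in this assay, chloro in place of fluoro on an aromatic carbon para to a large group gives a 1.6-fold lower number from compound 2 to compound 3 (0.21 log units; within the scatter). A step of this size cannot be told apart from the ordinary spread of repeated measurements, so the 4-fluorophenyl and 4-chlorophenyl versions count as equal here, and the pair gives no direction for this swap. Nothing shown here explains how the two groups compare at this position, and no supporting measurement bears on the result.

The compounds shown leave open whether a group of a different kind at this same position, such as an amine, a carboxylic acid or a longer chain, would produce a step beyond the scatter, since fluoro and chloro are the only two groups compared there. Going by these compounds, it also remains open whether chloro in place of fluoro would read the same in compound 1, where the 4-fluorophenyl group sits on the shared core instead of on the amino end of the chain.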